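From Hydroxy to Nitro in a Cytotoxic Series

The compounds below may be only part of what the source reports. "The series", "measured", "known", "first", "only" and "open" are said of these compounds alone.

Measured in a functional assay on HT-29 cells (Homo sapiens) for cytotoxicity, read by sulforhodamine B assay, with a stated time of 72 h; on this read-out higher numbers stand for weaker inhibition and lower numbers for stronger inhibition:
- compound 1 `COc1ccc(/C=C\c2cc(OC)c(OC)c(OC)c2)cc1[N+](=O)[O-]`: 113 nM
- compound 2 `COc1ccc(/C(F)=C\c2cc(OC)c(OC)c(OC)c2)cc1O`: 28.9 nM
- compound 3 `COc1ccc(/C(F)=C(/F)c2cc(OC)c(OC)c(OC)c2)cc1N`: 4.5 nM

Compound 2, at 28.9 nM, stands in the middle of these three numbers. Its gaps to compound 1 above it and compound 3 below it both lie beyond the usual scatter. The next compound to be tested is compound 4 `COc1ccc(/C(F)=C\c2cc(OC)c(OC)c(OC)c2)cc1[N+](=O)[O-]`, which has nitro in place of hydroxy on an aromatic carbon, ortho to a methoxy group: nitro in place of hydroxy on an aromatic carbon.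

Within the data shown here, no two measured compounds differ in one place only, so no direct precedent exists for this change. Among the measured compounds shown here, the closest guide is compound 1, which also carries nitro and gives 113 nM, the highest number so far. A moderate move toward weaker inhibition is therefore expected in this assay, probably beyond the scatter, though with real uncertainty. The expected step is a 2.8-fold higher number from compound 2 to compound 4 (0.44 log units; beyond the scatter). For compound 4 the estimate is 80 nM, with an expected range of 20 nM to 300 nM.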

Compound 4, half-maximal inhibitory concentration: 202 nM
For compound 4 the middle estimate is 2.5-fold (0.40 log units) below the measured one; measured number inside the range.
By their numbers in this assay, from the lowest: compound 3; then compound 2; then compounds 1 and 4 (each within the scatter of the next).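

Among these compounds, this is the first direct reading of a single change: replacing hydroxy with nitro on this aromatic carbon, ortho to a methoxy group, gives a 7.0-fold higher number from compound 2 to compound 4 (0.84 log units; beyond the scatter) in this assay and shows that the result depends on which of these two groups sits at this position. Compound 1 gives 113 nM and compound 4 gives 202 nM in the same test, and these values lie within the usual scatter of each other, so these two nitro compounds read alike even though only compound 4 carries the fluorine. No measured property is available to explain the step.

From the compounds shown here alone, it remains open whether the same replacement would give a step of similar size in another compound of the series. Going by these compounds, how a nitrile or a carboxylic acid would read at this position also remains open.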